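A few compounds are considered here, and "the series" means these few. Any claim that something is new, unique, unknown or untested is made for them only; others in the source may bear on it.

Working notes on the series. In a functional assay on DWD cells (Homo sapiens) for inhibition, read by sulforhodamine B assay (on this read-out higher numbers stand for weaker inhibition of growth and lower numbers for stronger inhibition of growth), compound 3 (`Oc1cccc2[nH]c(-c3ccc(-c4ccc(-c5ccccc5)cc4)cc3)nc12`) gives the lowest number of the three measured compounds (9680 nM). Compound 1 (`c1ccc(-c2ccc(-c3ccc(-c4nc5ccccc5[nH]4)cc3)cc2)cc1`) reads higher (100000 nM), and compound 2 (`FC(F)(F)c1ccc(-c2ccc(-c3ccc(-c4nc5ccccc5[nH]4)cc3)cc2)cc1`) reads the same (100000 nM), so both lie beyond the scatter from compound 3.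

The next compound is compound 4 (`Oc1cccc2[nH]c(-c3ccc(-c4ccc(-c5ccc(C(F)(F)F)cc5)cc4)cc3)nc12`), with the change trifluoromethyl in place of hydrogen on an aromatic carbon being trifluoromethyl in place of hydrogen on an aromatic carbon, para to a large group.

Within the data shown here, two measured steps bear on it. The same replacement appears only once, as no change at the digits printed from compound 1 to compound 2 (within the scatter) in the series without the hydroxy group. The large step, a 10-fold lower number from compound 1 to compound 3 (1.01 log units; beyond the scatter) for hydroxy in place of hydrogen, is a different change and is already present in compound 3. The data do not show whether the trifluoromethyl result carries over once the hydroxy group is there.

The expected outcome is therefore no step beyond the scatter, estimated as a 1.4-fold lower number from compound 3 to compound 4 (0.14 log units; within the scatter) in this direction. For compound 4 the estimate is 7000 nM with an expected range from 2000 nM to 30000 nM as its upper end.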

Compound 4, concentration for 50% growth inhibition: 3180 nM
Beside the measured number, compound 4's estimate is 2.2-fold (0.34 log units) above it, within the range that was stated.
By their numbers in this assay, from the lowest: compound 4; then compound 3; then compounds 1 and 2 (each within the scatter of the next).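

With the hydroxy group present, trifluoromethyl in place of hydrogen, para to a large group, now registers in this assay as a 3.0-fold lower number from compound 3 to compound 4 (0.48 log units; beyond the scatter), so the flat result without the hydroxy group does not carry over: the same change on two cores in this assay, no change at the digits printed (within the scatter) from compound 1 to compound 2 and a 3.0-fold lower number (0.48 log units; beyond the scatter) from compound 3 to compound 4, 3.0-fold (0.48 log units) apart, beyond the scatter of two such steps

Read the other way, hydroxy in place of hydrogen gives a 31-fold lower number from compound 2 to compound 4 (1.50 log units; beyond the scatter), a larger step than the one on the core of compound 1: the same change on two cores in this assay, a 10-fold lower number (1.01 log units; beyond the scatter) from compound 1 to compound 3 and a 31-fold lower number (1.50 log units; beyond the scatter) from compound 2 to compound 4, 3.0-fold (0.48 log units) apart, beyond the scatter of two such steps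

The two changes are therefore not independent in these four compounds.

Only trifluoromethyl is shown at this position, and it remains open whether a carboxylic acid or a methoxy group there would also give a lower number with the hydroxy group present. As far as these compounds go, it is also open whether an amine in place of the hydroxy group would show the same dependence.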